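From 2-Chlorophenyl to 3-Cyanophenyl on the Shared Core

The compounds below may be only part of what the source reports. "The series", "measured", "known", "first", "only" and "open" are said of these compounds alone.

Of the compounds shown here, three built on one core have been measured so far. Compound 1 `CC1(C)[C@H]2CC[C@]1(C)N(Cc1cn(-c3ccccc3O)nn1)C(=O)C2` gives 230 nM in a functional assay on PANC-1 cells (Homo sapiens) for inhibition, read by MTT assay, with a stated time of 24 h; a lower number here means a stronger inhibitor, a higher number a weaker inhibitor. Compound 2 `COc1ccc(-n2cc(CN3C(=O)C[C@@H]4CC[C@@]3(C)C4(C)C)nn2)cc1` gives 330 nM in this assay, and compound 3 `CC1(C)[C@H]2CC[C@]1(C)N(Cc1cn(-c3ccccc3Cl)nn1)C(=O)C2` gives 270 nM in this assay. Every step among them stays inside the usual scatter: a 1.4-fold higher number from compound 1 to compound 2 (0.16 log units; within the scatter), a 1.2-fold higher number from compound 1 to compound 3 (0.07 log units; within the scatter), and a 1.2-fold lower number from compound 2 to compound 3 (0.09 log units; within the scatter). Compound 3 therefore sits between the other two on the numbers, closer to compound 1 than to compound 2, yet separated from neither by more than the scatter.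

Compound 4 `CC1(C)[C@H]2CC[C@]1(C)N(Cc1cn(-c3cccc(C#N)c3)nn1)C(=O)C2` is not yet measured. It differs from compound 3 in one place: 3-cyanophenyl in place of 2-chlorophenyl on an aromatic nitrogen. The two steps that bear on this change are those that also swap the aryl group on the aromatic nitrogen, from compound 1 to compound 2 and from compound 2 to compound 3, and both were within the scatter. Compound 4 is therefore expected to show no step beyond the scatter, a 1.0-fold higher number from compound 3 to compound 4 (0.02 log units; within the scatter). The estimate for compound 4 in this assay is 280 nM, with a range from 140 nM to 560 nM.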

Compound 4, half-maximal inhibitory concentration: 260 nM
Beside the measured number, compound 4's estimate is 1.1-fold (0.03 log units) above it; measured number inside the range.
By their numbers in this assay, from the lowest: compounds 1, 4, 3 and 2 (each within the scatter of the next).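

In this assay the 3-cyanophenyl group of compound 4 brings a nitrile, with its triple bond and one hydrogen-bond acceptor, onto the aromatic nitrogen of the shared core, and the result is a 1.0-fold lower number from compound 3 to compound 4 (0.02 log units; within the scatter) together with a 1.3-fold lower number from compound 2 to compound 4 (0.10 log units; within the scatter) and a 1.1-fold higher number from compound 1 to compound 4 (0.05 log units; within the scatter) on the same core. Among these compounds, this position has now taken a fourth substituted phenyl, the first carrying a nitrile rather than a hydroxy, chloro or methoxy group, and no step among the four compounds goes beyond the scatter. Nothing available here speaks to why the numbers stay so close across these groups.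

Going by these compounds, all four compounds carry a substituted phenyl on this nitrogen, so it remains open whether an amine, a carboxylic acid or a longer alkyl chain on that ring would leave the number equally undisturbed. On these data alone, it is also open whether replacing the phenyl ring itself with a plain alkyl chain would hold the number in the same way.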